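The source may report more compounds than this note shows. Statements on the series, on what has been measured and on what is new or still open speak of the compounds shown alone.

Measured compounds:

- Compound 1, `CN(C(=O)NC(=O)c1ccc([N+](=O)[O-])cc1)c1nc(C(F)(F)F)c(C(=O)N/N=C/c2cccc(C(F)(F)F)c2)s1`: 4.39 ug/mL
- Compound 2, `CN(C(=O)NC(=O)c1ccc(Cl)cc1Cl)c1nc(C(F)(F)F)c(C(=O)N/N=C/c2ccc(C(F)(F)F)cc2)s1`: 8.42 ug/mL
- Compound 3, `CN(C(=O)NC(=O)c1ccc(Cl)c(Cl)c1)c1nc(C(F)(F)F)c(C(=O)N/N=C/c2ccc([N+](=O)[O-])cc2)s1`: 6.74 ug/mL

These three compounds were tested in a functional assay on MCF7 cells (Homo sapiens) for inhibition, read by MTT assay, with a stated time of 72 h; a higher number here means a weaker inhibitor, a lower number a stronger inhibitor. Compound 3, with 6.74 ug/mL, gives the second highest of the three numbers. Its nearest neighbour is compound 2, which gives 8.42 ug/mL, and the gap between the two lies within the usual scatter of this kind of measurement. The furthest number from it is that of compound 1, at 4.39 ug/mL, and that gap also lies within the scatter. On the numbers shown, then, none of the three can be set apart from the others.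

Compound 4, `CN(C(=O)NC(=O)c1ccc(F)c(F)c1)c1nc(C(F)(F)F)c(C(=O)N/N=C/c2ccc([N+](=O)[O-])cc2)s1`, has not yet been measured in this assay. It differs from compound 3 in one place:

3,4-difluorophenyl in place of 3,4-dichlorophenyl on a carbonyl carbon

Within the data shown here, no measured pair shows the effect of such a swap here, so there is no step to lean on. With the three known values sitting so close together, the expected step of a 1.3-fold higher number from compound 3 to compound 4 (0.10 log units; within the scatter) is small, most likely not beyond the scatter, with a slight lean towards a higher number. Compound 4 is therefore estimated at 8.5 ug/mL, with a range from 4.5 ug/mL to 17 ug/mL.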

Compound 4, half-maximal inhibitory concentration: 4.81 ug/mL
Compound 4: middle estimate off by 1.8-fold (0.25 log units), on the high side, within the range that was stated.
By their numbers in this assay, from the lowest: compounds 1, 4, 3 and 2 (each within the scatter of the next).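

In this assay the first pair differing in one place gives a 1.4-fold lower number from compound 3 to compound 4 (0.15 log units; within the scatter) when 3,4-difluorophenyl takes the place of 3,4-dichlorophenyl on a carbonyl carbon. Among these compounds, with the rest of the molecule held the same, the two halogens on this phenyl ring therefore cannot be told apart on these numbers, which the earlier compounds, each differing in several places, could not show. Nothing measured here bears on the reason for this result.

Still open, as far as these compounds go, is whether this position accepts groups other than halogens, such as a methoxy group, an amine or a carboxylic acid on the phenyl ring. This single pair also speaks for only one setting of the rest of the molecule, so the same swap in the other compounds remains an open question.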